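A few compounds are considered here, and "the series" means these few. Any claim that something is new, unique, unknown or untested is made for them only; others in the source may bear on it.

Of the compounds shown here, two have been measured in an ADME assay (liver) for metabolic stability, with Liver microsome (Homo sapiens) as the target, read by LC-MS, using microsomes and NADPH, with a stated time of 5 min, at 37 degrees C; on this read-out lower numbers stand for slow clearance and higher numbers for fast clearance. Compound 1 `CCn1c([C@@H](C)NS(=O)(=O)c2ccc(Cl)cc2)nc2cc(C(N)=O)ccc21` reaches only a limit of this assay, < 5 mL.min-1.g-1, so no number is known for it; that is the limit of < 5 mL.min-1.g-1 in this assay, at which 1 of the 2 values shown sits. Among the measured compounds shown here, compound 2 `CCn1c([C@@H](C)NS(=O)(=O)c2ccc(C#N)cc2)nc2ccc(C(F)(F)F)cc21` gives 34 mL.min-1.g-1 in this assay and so holds the only real number in the set, with no measured neighbour that differs from it in a single place. Compound 3 `CCn1c([C@@H](C)NS(=O)(=O)c2cnn(C(C)C)c2C)nc2ccc(C(F)(F)F)cc21` has not yet been measured. It differs from compound 2 in one place: 1-isopropyl-5-methyl-1H-pyrazol-4-yl in place of 4-cyanophenyl on a sulfonyl sulfur The swap exchanges one aromatic ring for another at the sulfonyl sulfur, and nothing measured here shows how such a swap moves clearance. The expected step from compound 2 to compound 3 is a 1.2-fold higher number from compound 2 to compound 3 (0.07 log units; within the scatter), which is not expected to go beyond the usual scatter. In this assay compound 3 is therefore estimated at 40 mL.min-1.g-1, within a range from 15 mL.min-1.g-1 to 110 mL.min-1.g-1.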

Compound 3, intrinsic clearance in microsomes: > 100 mL.min-1.g-1
Compound 3 gave a limit, no number; the forecaster's own chance of this, stated with the estimate: 10%; middle value at least 2.5-fold (0.39 log units) away from the limit.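

In this assay, 1-isopropyl-5-methyl-1H-pyrazol-4-yl in place of 4-cyanophenyl on a sulfonyl sulfur gives an at least 2.9-fold higher number from compound 2 to compound 3 (0.46 log units; beyond the scatter). Among the compounds shown here, this is the first pair that differs in one place, and it shows that the group on the sulfonyl sulfur can move clearance beyond the scatter, here towards faster clearance. The true size of the step stays unknown because compound 3 reaches a limit of the assay, not a number: the limit of > 100 mL.min-1.g-1 in this assay, at which 1 of the 3 values shown sits.

A single step cannot separate the roles of the ring, the isopropyl and the methyl, and a pyrazole carrying a methyl in place of the isopropyl, or a pyridine ring, could help to do so. Compound 1 differs from both other compounds in more than one place, so it cannot show how this change acts.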